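Changing One Aryl Group on a Weak Growth Inhibitor

The compounds below may be only part of what the source reports. "The series", "measured", "known", "first", "only" and "open" are said of these compounds alone.

Measured so far:
- compound 1 `COc1ccc(C(F)(F)F)cc1Nc1ncc(C(F)(F)F)c(N2Cc3cccc(N(C)S(C)(=O)=O)c3C2)n1`: > 30000 nM (a limit, not a number)
- compound 2 `COc1cc(Nc2ncc(C(F)(F)F)c(N3Cc4cccc(N(C)S(C)(=O)=O)c4C3)n2)cc(OC)c1`: 24800 nM

Both compounds were tested in a functional assay on A549 cells (Homo sapiens) for antiproliferative activity, read by spectrophotometry, with a stated time of 2 days; on this read-out lower numbers stand for stronger inhibition of growth and higher numbers for weaker inhibition of growth. Compound 1 gives > 30000 nM, which is a limit of the assay and not a number. Going by the values given here, compound 2 gives 24800 nM, the only true number so far, so there is no second number to rank it against.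

The next compound is compound 3 `CN(c1cccc2c1CN(c1nc(Nc3ccc(Cl)c(C(F)(F)F)c3)ncc1C(F)(F)F)C2)S(C)(=O)=O`. Its change from compound 2 is 4-chloro-3-(trifluoromethyl)phenyl in place of 3,5-dimethoxyphenyl on a nitrogen on an aromatic ring.

Among the compounds with values here, one measured step bears on this, as it swaps a group at the same place: an at least 1.2-fold lower number from compound 1 to compound 2 (0.08 log units; that floor lies within the scatter). Its floor lies within the scatter, so it shows no clear effect from a swap at this place. On these data alone, on that evidence, no step beyond the scatter is expected in this assay, and the direction stays open. The estimated change is a 1.4-fold lower number from compound 2 to compound 3 (0.14 log units; within the scatter). Compound 3 is expected at about 18000 nM, within an estimated range of 6000 nM to 30000 nM.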

Compound 3, concentration for 50% growth inhibition: 15200 nM
The estimate for compound 3 lay 1.2-fold (0.07 log units) above the measured number, within the range that was stated.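

Going by these compounds alone, this is the first step at this position between two true numbers, and it can be read in this assay: a 1.6-fold lower number from compound 2 to compound 3 (0.21 log units; within the scatter). The change replaces 3,5-dimethoxyphenyl, with its 2 hydrogen-bond acceptors, by 4-chloro-3-(trifluoromethyl)phenyl, with 0 hydrogen-bond acceptors, so even this exchange of substituents on the ring leaves no clear effect on growth inhibition, and the second comparison agrees: an at least 1.9-fold lower number from compound 1 to compound 3 (0.29 log units; that floor lies within the scatter). Compound 1 carries a limit and not a number, so that comparison gives only a floor, and its true size stays unknown: the limit of > 30000 nM in this assay, at which 1 of the 3 values shown sits.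

All three compounds carry a substituted phenyl ring on this nitrogen, so they cannot tell whether any group here can move the number beyond the usual scatter, or why these three do not. On these data alone, what a phenyl ring bearing an amine or a carboxylic acid would do at this place stays open, as does the effect of a saturated ring such as piperidine in place of the phenyl ring.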